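Furan in Place of Pyrrole on a Shared Acrylamide Core

The compounds below may be only part of what the source reports. "The series", "measured", "known", "first", "only" and "open" are said of these compounds alone.

Four compounds share a cyanoacrylamide core that carries a benzylamide on one side and a five-membered aromatic ring on the other. Compound 1 `COc1ccc(CNC(=O)/C(C#N)=C/c2ccc[nH]2)cc1` and compound 3 `COc1ccc(CNC(=O)/C(C#N)=C/c2ccco2)cc1` bear a methoxybenzyl amide; compound 2 `N#C/C(=C\c1ccc[nH]1)C(=O)NCc1ccc(Cl)c(Cl)c1` and compound 4 `N#C/C(=C\c1ccco1)C(=O)NCc1ccc(Cl)c(Cl)c1` bear a dichlorobenzyl amide. The difference between the core of compound 1 and the core of compound 2 is not broken down here.

In a functional assay on DU-145 cells (Homo sapiens) for inhibition, read by MTT assay, with a stated time of 72 h (on this read-out higher numbers stand for weaker inhibition of growth and lower numbers for stronger inhibition of growth), compound 1 reaches only the limit of the assay, > 50000 nM. Compound 2 likewise reaches only a limit in this assay, > 50000 nM. Compound 3 gives 29000 nM in this assay. The change furan-2-yl in place of 1H-pyrrol-2-yl on a double-bonded chain carbon bound to a double-bonded chain carbon therefore produced an at least 1.7-fold lower number from compound 1 to compound 3 (0.23 log units; that floor lies within the scatter). Its floor is set by the limit of > 50000 nM in this assay, at which 2 of the 3 values shown sit.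

The same change, (furan-2-yl in place of 1H-pyrrol-2-yl on a double-bonded chain carbon bound to a double-bonded chain carbon), leads from compound 2 to compound 4. Since compound 2 sits at its limit > 50000 nM and compound 1 moved by an at least 1.7-fold lower number from compound 1 to compound 3 (0.23 log units; that floor lies within the scatter), compound 4 is expected to change by an at least 1.4-fold lower number from compound 2 to compound 4 (0.15 log units; that floor lies within the scatter) in this assay. Compound 4 is thus estimated at 35000 nM in this assay, within 12000 nM to 100000 nM.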

Compound 4, concentration for 50% growth inhibition: 24000 nM
Compound 4: the middle estimate sits 1.5-fold (0.16 log units) above what was measured, and the stated range covers the measured number.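

On the dichlorobenzyl amide core, furan-2-yl in place of 1H-pyrrol-2-yl gives in this assay an at least 2.0-fold lower number from compound 2 to compound 4 (0.31 log units; beyond the scatter), and this step lies beyond the usual scatter, whereas the floor of the step on the methoxybenzyl amide core lies within it. The change therefore points the same way on both cores, which is some sign that it carries from one core to the other within these two pairs, but the two steps cannot be told apart in size: the same change on two cores in this assay, an at least 1.7-fold lower number (0.23 log units; that floor lies within the scatter) from compound 1 to compound 3 and an at least 2.0-fold lower number (0.31 log units; beyond the scatter) from compound 2 to compound 4; the limit leaves it open whether they differ. Going by these compounds, neither step gives a true size, only a floor, and the real gain from the furan-2-yl group on either core remains unknown because both steps start from a limit: the limit of > 50000 nM in this assay, at which 2 of the 4 values shown sit.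

The compounds shown leave open whether a thiophen-2-yl group, placed on the same double-bonded chain carbon, would follow the furan-2-yl compounds. They also leave open whether the change would carry to a core with a longer chain or an amine in place of the benzyl group.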